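The source may report more compounds than this note shows. Statements on the series, on what has been measured and on what is new or still open speak of the compounds shown alone.

Of the compounds shown here, two with the shared core have been measured in a functional assay on Bel7402/5-FU cells (Homo sapiens) for antiproliferative activity, read by MTT assay, with a stated time of 72 h; on this read-out higher numbers stand for weaker inhibition and lower numbers for stronger inhibition. Among the measured compounds shown here, compound 1 `COc1cccc(CNCc2c(C(=O)O)n(Cc3ccccc3)c3cc(C(C)C)ccc23)c1` gives 5920 nM in this assay, the lower of the two numbers so far. Compound 2 `COc1cccc(CNCc2c(C(=O)O)n(Cc3ccc(C)cc3)c3ccccc23)c1` gives 9330 nM in this assay, a number that sits within the scatter of compound 1, so the two cannot be told apart on potency. For the measured compounds named here, the two structures differ in more than one place, so their values show only that the two compounds behave alike here.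

The account now follows the step from compound 1 to compound 3 `COc1cccc(CNCc2c(C(=O)O)n(Cc3ccc(N)cc3)c3cc(C(C)C)ccc23)c1`. The change is amino in place of hydrogen on an aromatic carbon. Going by the values given here, no measured pair shows what this kind of change does on this series, so there is nothing in the data to set a direction. Compound 3 is expected to land close to compound 1, with a step of a 1.1-fold lower number from compound 1 to compound 3 (0.03 log units; within the scatter) that stays within the scatter in either direction. On that basis the estimate for compound 3 in this assay is 5500 nM, expected to fall between 2500 nM and 12000 nM.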

Compound 3, half-maximal inhibitory concentration: > 50000 nM
Compound 3: a limit, no number; the forecaster's own chance of this, stated with the estimate: 3%; at least 9.0-fold (0.95 log units) between middle value and limit.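

In this assay, the reading for compound 3 is a limit and not a number: the limit of > 50000 nM in this assay, at which 1 of the 3 values shown sits. Going from benzyl to 4-aminobenzyl gives an at least 8.4-fold higher number from compound 1 to compound 3 (0.92 log units; beyond the scatter), so this aromatic carbon, para to a large group, is a place where a single change moves the read-out well beyond the scatter, something the earlier pair could not show, as its members differ in more than one place. The change adds only one heavy atom, yet it is enough to carry the compound to the limit of the read-out, and the step marks only the smallest size the change can have, with its full size still unknown.

The compounds shown leave open whether this loss belongs to the amino group itself or would also follow from a hydroxyl, a methoxy or an acetamide on the same carbon. They also leave open whether an amino group on another carbon of this ring, or one carried at the end of a longer chain, would have the same effect on this read-out.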